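Ring enlargement at the amide of compound 2

A few compounds are considered here, and "the series" means these few. Any claim that something is new, unique, unknown or untested is made for them only; others in the source may bear on it.

Compounds measured so far:
compound 1, `C[C@@H]1N[C@H](C(=O)N2CCC[C@H]2C#N)C[C@@H]1C(=O)N1CCOCC1`, 94%;
compound 2, `C[C@@H]1N[C@H](C(=O)N2CCC[C@H]2C#N)C[C@@H]1C(=O)N1CCCC1`, 94%;
compound 3, `CN(C)C(=O)[C@@H]1CN[C@H](C(=O)N2CCC[C@H]2C#N)C1`, 76%.

In an assay on the whole organism (plasma, strain Sprague-Dawley) for inhibition of Dipeptidyl peptidase 4 (Rattus norvegicus), with a stated time of 6 h, at a dose of 1 mg/kg by the oral route (on this read-out higher numbers stand for more inhibition at the one dose given (going by the name of the read-out) and lower numbers for less inhibition), compound 2 stands level with compound 1 at the digits shown, and the two together give the highest numbers of the three, while compound 3 sits lower by an amount beyond the scatter. Compound 4, `C[C@@H]1N[C@H](C(=O)N2CCC[C@H]2C#N)C[C@@H]1C(=O)N1CCCCC1`, has not yet been measured. It differs from compound 2 at one point: piperidin-1-yl in place of pyrrolidin-1-yl on a carbonyl carbon. Among the compounds with values here, the one measured step that touches the same carbonyl carbon is no change at the digits printed from compound 1 to compound 2 (within the scatter), where the ring on that amide was exchanged without any change in the read-out. Because of no change at the digits printed from compound 1 to compound 2 (within the scatter) the step of a number 4 percentage points lower from compound 2 to compound 4 (within the scatter) is expected to stay within the scatter. Compound 4 is therefore estimated at 90%, with a range from 78% to 97%.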

Compound 4, a percentage reported as inhibition, in the whole organism at one dose (the size of the read-out at that dose, not a potency): 91%
Compound 4: middle estimate off by 1 percentage points, on the low side, and the stated range covers the measured number.
By their numbers in this assay, from the lowest: compound 3; then compounds 4, 1 and 2 (each within the scatter of the next).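

In this assay, piperidin-1-yl on the carbonyl carbon gives a number 3 percentage points lower from compound 2 to compound 4 (within the scatter), and set against morpholin-4-yl it gives a number 3 percentage points lower from compound 1 to compound 4 (within the scatter). The six-membered ring without a second hetero atom therefore reads alike with both earlier rings, so this amide position accepts all three at this one dose. The read-out gives the size of the effect at that dose, not a potency, so any difference in potency among the three stays hidden.

Nothing measured here explains this sameness. On these data alone, whether an open-chain diethylamino group on the carbonyl carbon, or a carboxylic acid replacing the amide, would hold the number stays open.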